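The source may hold more compounds than are shown below. What is called first, only, known or untested is meant among the compounds shown, and "the series" means these compounds.

Series notes. Compound 2 `COc1ccc([C@H]2CC(=O)N(c3ccc(N)cc3)C2)cc1OC1CCCC1` sits in a functional assay on HEK293 cells (Homo sapiens) for cytotoxicity (a lower number here means that less compound is tolerated, a higher number that more compound is tolerated), at a limit of the assay: compound 2 gives > 10000 nM. Compound 1 `COc1ccc([C@H]2CC(=O)N(c3cccc(N)c3C)C2)cc1OC1CCCC1` rests at the same limit, and in this assay compound 1 gives > 10000 nM. Among the compounds with values here, the only measured step, a step that the two limits leave unreadable from compound 1 to compound 2, is accordingly unreadable, and the limit of > 10000 nM in this assay, at which 2 of the 2 values shown sit, is the whole of the evidence. Compound 3 `COc1ccc([C@H]2CC(=O)N(c3ccc([S+](C)[O-])cc3)C2)cc1OC1CCCC1` differs from compound 2 in one place: a group of 3 heavy atoms (1 carbon, 1 oxygen, 1 sulfur; no ring) in place of one nitrogen atom, on an aromatic carbon. Within the data shown here, no measured step bears on this change. Compound 3 is expected to remain near the limit, estimated at 12000 nM with a range of 4000 nM to 40000 nM. The implied step that the limit leaves unreadable from compound 2 to compound 3 is expected to fall within the scatter.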

Compound 3, half-maximal cytotoxic concentration: 7510 nM
Beside the measured number, compound 3's estimate is 1.6-fold (0.20 log units) above it, within the range that was stated.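

In this assay compound 3 gives 7510 nM, a measured number. The earlier values in the series were limits, so the replacement of amino on this aromatic carbon, para to a large group, yields the first readable value. The change reads as an at least 1.3-fold lower number from compound 2 to compound 3 (0.12 log units; that floor lies within the scatter), and as an at least 1.3-fold lower number from compound 1 to compound 3 (0.12 log units; that floor lies within the scatter), so neither floor establishes a real shift. The step from compound 1 to compound 2 cannot be read, and most of the data remain limits: the limit of > 10000 nM in this assay, at which 2 of the 3 values shown sit.

Open, going by these compounds, is how a carboxylic acid or a longer chain on this aromatic carbon would read in this assay. Also open, on these data alone, is whether any group here gives a step beyond the scatter.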